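The source may hold more compounds than are shown below. What is called first, only, known or untested is meant among the compounds shown, and "the series" means these compounds.

Three compounds share one core and differ only in the aromatic group at the end of a double-bonded chain. Compound 1 `CC1(C)CCC[C@]2(C)[C@@H](CC[C@@](C)(O)/C=C/c3ccccc3)[C@](C)(O)CC[C@@H]12` carries a plain phenyl there and, in a functional assay on PC-3 cells (Homo sapiens) for cytotoxicity, read by MTT assay, with a stated time of 48 h (on this read-out lower numbers stand for stronger inhibition and higher numbers for weaker inhibition), compound 1 gives 121 nM, the lowest of the three numbers. Compound 2 `CC1(C)CCC[C@]2(C)[C@@H](CC[C@@](C)(O)/C=C/c3ccc(Cl)nc3)[C@](C)(O)CC[C@@H]12` gives 275 nM, and compound 3 `COc1cccc(/C=C/[C@](C)(O)CC[C@@H]2[C@@]3(C)CCCC(C)(C)[C@@H]3CC[C@@]2(C)O)c1OC` gives 2900 nM. The step of a 2.3-fold higher number from compound 1 to compound 2 (0.36 log units; beyond the scatter) is modest, while the step of a 24-fold higher number from compound 1 to compound 3 (1.38 log units; beyond the scatter) is large, and an 11-fold higher number from compound 2 to compound 3 (1.02 log units; beyond the scatter) is large as well; compound 1 is therefore the most potent of the three, with every step away from it beyond the scatter.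

Compound 4 `CC1(C)CCC[C@]2(C)[C@@H](CC[C@@](C)(O)/C=C/c3ccc(F)cc3)[C@](C)(O)CC[C@@H]12` is the next member. Its difference from compound 1 is fluoro in place of hydrogen on an aromatic carbon, sitting para to a large group. Among the measured compounds shown here, no measured pair shows this exact change: the two measured steps from compound 1 both replace the whole phenyl, with the smaller change in compound 2 costing less than the larger change in compound 3. A single fluoro is a smaller alteration than either, so in this assay compound 4 is expected to land close to compound 1, at most a slight weakening, as a step of a 1.5-fold higher number from compound 1 to compound 4 (0.17 log units; within the scatter). The estimated value for compound 4 is 180 nM, with a likely range from 70 nM to 500 nM.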

Compound 4, half-maximal inhibitory concentration: 82 nM
Compound 4: the middle estimate sits 2.2-fold (0.34 log units) above what was measured; the measured number falls inside the stated range.
By their numbers in this assay, from the lowest: compounds 4 and 1 (each within the scatter of the next); then compound 2; then compound 3.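

In this assay, fluoro in place of hydrogen on an aromatic carbon, para to a large group, gives a 1.5-fold lower number from compound 1 to compound 4 (0.17 log units; within the scatter) and so leaves the number at this position indistinguishable from that of the plain phenyl. The 4-fluorophenyl group also stays clearly apart from the two other aromatic groups, with a 3.4-fold lower number from compound 2 to compound 4 (0.53 log units; beyond the scatter) and a 35-fold lower number from compound 3 to compound 4 (1.55 log units; beyond the scatter) showing that a phenyl carrying one added atom can keep the level of compound 1 while the 6-chloropyridin-3-yl and 2,3-dimethoxyphenyl groups of compounds 2 and 3 do not. Nothing measured here explains why these groups differ as they do.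

These four compounds cannot show how much room this position really has, as fluoro is a single atom and the result says nothing about whether a trifluoromethyl group, an amine or a carboxylic acid in the same place would hold the number or lose it. Going by these compounds, it also stays open whether fluoro on a different carbon of the ring would behave as it does here.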